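This account rests on a few compounds, and the source may have more. Where it says the series, first, only, none or still open, it means among the compounds named here.

Working notes on the series. Compound 1 `Brc1cncc(OC[C@@H]2CCN2)c1` in an assay on brain for binding affinity to Neuronal acetylcholine receptor; alpha4/beta2 (Rattus norvegicus), read by radioligand binding (a lower number here means a stronger inhibitor, a higher number a weaker inhibitor), gives 0.18 nM. Going by the values given here, compound 2 `Clc1cc(OC[C@@H]2CCN2)cnc1Cl` in this assay gives 0.023 nM, the lowest of the two numbers measured so far; the gap between compound 2 and compound 1 lies beyond the usual scatter, so compound 2 stands as the tighter binder of the pair.

Compound 3 `Clc1ncc(OC[C@@H]2CCN2)cc1Br` is not yet measured. Relative to compound 2 the change is bromo in place of chloro on an aromatic carbon, a bromo in place of chloro on an aromatic carbon, with the rest of the structure held. Among the compounds with values here, no measured pair isolates this exact exchange, so there is no step to lean on; the expected step of a 1.3-fold higher number from compound 2 to compound 3 (0.12 log units; within the scatter) is therefore small, with no direction claimed beyond the scatter. On that basis compound 3 is estimated at 0.03 nM in this assay, with a plausible range from 0.01 nM to 0.09 nM, pending the measurement.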

Compound 3, inhibition constant: 0.015 nM
Beside the measured number, compound 3's estimate is 2.0-fold (0.30 log units) above it, and the stated range covers the measured number.
By their numbers in this assay, from the lowest: compounds 3 and 2 (each within the scatter of the next); then compound 1.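

In this assay, bromo in place of chloro on the aromatic carbon ortho to a chloro group gives a 1.5-fold lower number from compound 2 to compound 3 (0.19 log units; within the scatter) and so stays within the scatter: at this position, compounds 2 and 3 do not separate the two halogens. Chloro in place of hydrogen on an aromatic carbon, with the rest of compound 1 held, gives a 12-fold lower number from compound 1 to compound 3 (1.08 log units; beyond the scatter) and is the only one-place step in the series that lies beyond the scatter. Nothing available explains either step.

As far as these compounds go, only hydrogen, chloro and bromo appear at the positions compared here, so the effect of a fluoro, methyl, methoxy or amine group remains open. From the compounds shown here alone, whether the large step carries over to a compound with chloro in place of the bromo of compound 1 also remains open.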